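Furan-2-yl for thiophen-3-yl at the saturated ring carbon

The source may hold more compounds than are shown below. What is called first, only, known or untested is meant among the compounds shown, and "the series" means these compounds.

Measured so far:
compound 1 `CC(C)OC(=O)C1=C(C(F)(F)F)NC(=O)NC1c1ccsc1` — 651 nM
compound 2 `CC1=C(C(=O)OC(C)C(F)(F)F)C(c2ccoc2)NC(=O)N1` — 234 nM

Within the data shown here, in an assay on HEK293 cells for displacement of a labelled ligand from adenosine receptor A2b (Homo sapiens), read by radioligand binding, with a stated time of 30 min (on this read-out higher numbers stand for weaker inhibition and lower numbers for stronger inhibition), compound 1 gives 651 nM, the higher of the two numbers so far; compound 2 gives 234 nM, a lower number, and the gap between them lies beyond the usual scatter. Compound 2 differs from compound 1 in several places at once, so nothing about any single change can be read from that pair.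

Compound 3 `CC(C)OC(=O)C1=C(C(F)(F)F)NC(=O)NC1c1ccco1` is not yet measured. It differs from compound 1 in one place: furan-2-yl in place of thiophen-3-yl on a saturated ring carbon. Among the measured compounds shown here, no measured pair isolates this exchange, so the expected size of the step is uncertain. The step of a 1.4-fold lower number from compound 1 to compound 3 (0.16 log units; within the scatter) is estimated as small, within the scatter, with a slight lean toward a lower number. Compound 3 is expected to give about 450 nM, within 150 nM to 1400 nM.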

Compound 3, inhibition constant: 238 nM
For compound 3 the middle estimate is 1.9-fold (0.28 log units) above the measured one, and the stated range covers the measured number.
By their numbers in this assay, from the lowest: compounds 2 and 3 (each within the scatter of the next); then compound 1.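

In this assay, the saturated ring carbon is sensitive to the choice of five-membered aromatic ring: furan-2-yl in place of thiophen-3-yl gives a 2.7-fold lower number from compound 1 to compound 3 (0.44 log units; beyond the scatter) with the rest of the structure unchanged. The exchange swaps sulfur for oxygen and also moves the point of attachment, so this single pair cannot separate the two. Nothing available accounts for the step.

Open, as far as these compounds go, is how thiophen-2-yl would compare, which would isolate the hetero atom from the attachment point. Also open, from the compounds shown here alone, is whether a phenyl ring is tolerated on this carbon.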